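The source may hold more compounds than are shown below. What is called first, only, known or untested is meant among the compounds shown, and "the series" means these compounds.

Measured in an ADME assay on L929 cells (Mus musculus) for cytotoxicity, read by resazurin assay, with a stated time of 72 h; a higher number here means a weaker inhibitor, a lower number a stronger inhibitor:
- compound 1 `O=C(/C=C/c1ccc2c(c1)B(O)OC2)c1ccccn1`: > 10 ug/mL
- compound 2 `COc1cc(C(=O)/C=C/c2ccc3c(c2)B(O)OC3)cc(OC)c1OC`: > 10 ug/mL
- compound 3 `COc1cccc(C(=O)/C=C/c2ccccc2)c1`: 5.7 ug/mL

In this assay compound 1 gives > 10 ug/mL, which is a limit and not a number. Its position is the limit of > 10 ug/mL in this assay, at which 2 of the 3 values shown sit. Compound 2 gives > 10 ug/mL, which is also a limit. Within the data shown here, compound 3 gives 5.7 ug/mL, the only true number so far.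

Compound 4 `O=C(/C=C/c1ccc2c(c1)B(O)OC2)c1ccccc1` carries phenyl in place of pyridin-2-yl on a carbonyl carbon. Among the measured compounds shown here, no measured step shows the size of this change directly. In this assay the expectation is a small change, either none beyond the scatter or a modest move towards a stronger inhibitor. Compound 2, at > 10 ug/mL, keeps a limit result for compound 4 likely. Compound 3, at 5.7 ug/mL, keeps a true number possible. The estimated step of an at least 1.1-fold lower number from compound 1 to compound 4 (0.04 log units; that floor lies within the scatter) is expected to be small. For compound 4 the estimated value is 9 ug/mL, with an expected range of 4 ug/mL to 20 ug/mL.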

Compound 4, half-maximal inhibitory concentration: > 10 ug/mL
Compound 4: only a limit was reported (the forecaster's own chance of this, stated with the estimate: 55%); middle value at least 1.1-fold (0.04 log units) away from the limit.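

No step can be read from compound 1 to compound 4 in this assay, as both results are limits and not numbers: the limit of > 10 ug/mL in this assay, at which 3 of the 4 values shown sit.

From the compounds shown here alone, whether phenyl in place of pyridin-2-yl on a carbonyl carbon changes the result in this assay at all stays open.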